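Swapping an Aminopyrimidine for an Aminopyrazole on a Shared Core

This account rests on a few compounds, and the source may have more. Where it says the series, first, only, none or still open, it means among the compounds named here.

Measured compounds:
- compound 1 `Fc1ccc(-c2nn3c(NC4CCCC4)cccc3c2-c2ccoc2)cc1` — "not determined" (no result reported)
- compound 2 `Nc1nccc(-c2c(-c3ccc(F)cc3)nn3c(NC4CCCC4)cccc23)n1` — 46000 nM
- compound 3 `Cc1nc(-c2c(-c3ccc(F)cc3)nn3c(NC4CCCC4)cccc23)co1` — "not determined" (no result reported)

Three compounds built on the same fused core were tested in an ADME assay on Vero cells (Chlorocebus sabaeus) for cytotoxicity; on this read-out higher numbers stand for lower toxicity in this test and lower numbers for higher toxicity in this test. Compound 1 and compound 3 carry a furan or a methyl-oxazole on the core, but for neither of them was a number reported: compound 1 gives "not determined" (no result reported) and compound 3 gives "not determined" (no result reported). Going by the values given here, compound 2, which bears a 2-aminopyrimidin-4-yl group, is therefore the only one with a value: in this assay compound 2 gives 46000 nM, a concentration that lies far in the weakly toxic region. With a single number there is no comparison to draw among the measured compounds.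

Compound 4 `Nc1n[nH]cc1-c1c(-c2ccc(F)cc2)nn2c(NC3CCCC3)cccc12` is the next step. It differs from compound 2 in one place: 3-amino-1H-pyrazol-4-yl in place of 2-aminopyrimidin-4-yl on an aromatic carbon. Among the compounds with values here, no step between measured compounds is available to guide the estimate, so the expectation rests on the change itself. Because compound 2 gives 46000 nM and the exchange keeps one small amino-bearing aromatic ring for another, the step of a 1.2-fold lower number from compound 2 to compound 4 (0.06 log units; within the scatter) is expected to stay within the scatter, with no clear direction. Compound 4 is estimated at 40000 nM, in a range from 15000 nM to 110000 nM.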

Compound 4, half-maximal cytotoxic concentration: 20000 nM
Compound 4: the middle estimate sits 2.0-fold (0.30 log units) above what was measured, within the range that was stated.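

In this assay, the exchange of 2-aminopyrimidin-4-yl for 3-amino-1H-pyrazol-4-yl gives a 2.3-fold lower number from compound 2 to compound 4 (0.36 log units; beyond the scatter), the first sign that the read-out responds to what sits on this aromatic carbon, next to the ring atom that bears a 4-fluorophenyl group. The step is modest, but it shows that two amino-bearing aromatic rings are not interchangeable here, even though one is six-membered and the other five-membered and they differ by only a single heavy atom. No measurement shown here explains the step, so which part of the exchange accounts for it stays unknown.

Going by these compounds alone, the furan of compound 1 and the methyl-oxazole of compound 3 carry no number, so no step involving either can be read, and it remains unclear how rings without an amino group compare on this core. From the compounds shown here alone, how far the read-out would move with a plain phenyl ring, or with an open-chain amine or a carboxylic acid on this carbon, also remains open.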